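Two Measured Analogues and an Iodophenyl Variant Awaiting Its Number

A few compounds are considered here, and "the series" means these few. Any claim that something is new, unique, unknown or untested is made for them only; others in the source may bear on it.

Two compounds from this series carry numbers in a functional assay (muscle tissue) with Cavia porcellus as the target; on this read-out lower numbers stand for an effect already at smaller amounts and higher numbers for an effect only at larger amounts of compound. Compound 1 `COC(=O)C1=C(C)NC(C)=C(C(=O)OC)C1c1ccccc1` gives 28.2 nM, and compound 2 `COC(=O)C1=C(C)N=C(C)/C(=C(\O)OC)C1c1ccccc1F` gives 42.7 nM. Compound 2 thus holds the higher of the two numbers, but its gap to compound 1 sits within the usual scatter of repeated measurements, so the two readings cannot be told apart with confidence. Within the data shown here, no pair of measured compounds differs in only one place, so no single structural step has yet been tied to a change in this assay.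

Compound 3 `COC(=O)C1=C(C)N=C(C)/C(=C(\O)OC)C1c1cccc(I)c1` has not yet been measured. It differs from compound 2 in one place: 3-iodophenyl in place of 2-fluorophenyl on a saturated ring carbon. Among the measured compounds shown here, with no measured step to lean on, the expectation for compound 3 stays close to compound 2, with a step of a 1.2-fold lower number from compound 2 to compound 3 (0.09 log units; within the scatter) that is estimated to remain within the scatter. Compound 3 is therefore expected to give about 35 nM, with a range from 10 nM to 120 nM.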

Compound 3, half-maximal effective concentration: 41.7 nM
Beside the measured number, compound 3's estimate is 1.2-fold (0.08 log units) below it; the range from low to high includes it.
By their numbers in this assay, from the lowest: compounds 1, 3 and 2 (each within the scatter of the next).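

In this assay, among these compounds, the exchange of 2-fluorophenyl for 3-iodophenyl on the saturated ring carbon provides the first step that can be read between two measured compounds (a 1.0-fold lower number from compound 2 to compound 3 (0.01 log units; within the scatter)). The step lies within the scatter, so at this position the two substituted phenyl groups cannot be told apart on this read-out, even though the entering group carries iodine rather than fluorine. No available evidence accounts for this outcome.

The step changes both the halogen and its position on the phenyl ring, so it cannot show what either change would do alone. It also leaves open whether a phenyl ring bearing a nitro group, an amine or a carboxylic acid would give a reading that can be told apart from these.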